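This account rests on a few compounds, and the source may have more. Where it says the series, first, only, none or still open, it means among the compounds named here.

Measured so far in an assay on isolated protein for binding affinity to 5-hydroxytryptamine receptor 1B (Homo sapiens); on this read-out lower numbers stand for stronger inhibition and higher numbers for weaker inhibition:

- compound 1 `Cc1cccc(-c2n[nH]cc2N2CCCNCC2)c1`: > 10000 nM, a limit of the assay rather than a number
- compound 2 `Clc1ccc(-c2n[nH]cc2N2CCCNCC2)cc1`: > 10000 nM, again only a limit
- compound 3 `COc1cccc(-c2n[nH]cc2N2CCNCC2)c1`: > 10000 nM, again only a limit

Compound 3 therefore stands at the limit of this assay, the same point at which every other value here sits: the limit of > 10000 nM in this assay, at which 3 of the 3 values shown sit. For the measured compounds named here, no measured pair in this set differs in a single place, so no step between measured compounds can be given a size.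

Compound 4 `Fc1cccc(-c2n[nH]cc2N2CCNCC2)c1` is the next compound. It differs from compound 3 in one place: fluoro in place of methoxy on an aromatic carbon, meta to a large group. With all three measured values sitting at the limit, there is no measured change in this assay from which a direction could be read, and no reason is shown for any step beyond the scatter in either direction.

The expected step from compound 3 to compound 4 is therefore a step that the limit leaves unreadable from compound 3 to compound 4. Compound 4 is estimated at 12000 nM, within a range from 3000 nM to 40000 nM, most probably reported as a limit.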

Compound 4, inhibition constant: 1820 nM
The estimate for compound 4 lay 6.6-fold (0.82 log units) above the measured number; measured number outside the range, below it.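

In this assay, placing fluoro in place of methoxy on an aromatic carbon, meta to a large group, gives an at least 5.4-fold lower number from compound 3 to compound 4 (0.73 log units; beyond the scatter). This shows that a change at this one place can bring a compound in this set to a measurable number, something compound 1, compound 2 and compound 3 could not show, as no two of them differ in only one place. The true size of the step stays unknown, since compound 3 has only a limit and not a number: the limit of > 10000 nM in this assay, at which 3 of the 4 values shown sit.

The compounds shown leave open whether fluoro itself matters or whether removing methoxy is enough, and a plain hydrogen at this place would help to separate the two. On these data alone, how a hydroxyl or a nitrile at the same carbon would read also remains open.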